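This account rests on a few compounds, and the source may have more. Where it says the series, first, only, none or still open, it means among the compounds named here.

Measured so far:
Compound 1 `O=c1c2ccccc2c(-c2cccnc2)nn1CCNS(=O)(=O)c1ccccc1`: 26300 nM
Compound 2 `CCn1nc(-n2ccnc2)c2ccccc2c1=O`: 5370 nM

In a functional assay (trachea) with Cavia porcellus as the target (on this read-out higher numbers stand for weaker inhibition and lower numbers for stronger inhibition), compound 2 gives 5370 nM. This is the lower of the two numbers and so the stronger inhibition, and its gap to compound 1 at 26300 nM lies beyond the usual scatter of repeated measurements.

The next compound to be measured is compound 3 `CCn1nc(-c2cnccn2)c2ccccc2c1=O`. It keeps the shared core and the ethyl group of compound 2, and one group changes: pyrazin-2-yl stands in place of 1H-imidazol-1-yl on an aromatic carbon (pyrazin-2-yl in place of 1H-imidazol-1-yl on an aromatic carbon).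

Going by the values given here, no two measured compounds differ in only one place, so the data give no direct guide to the size of this step. Among the compounds with values here, with compound 2 at the lower of only two numbers, a modest move towards weaker inhibition in this assay is expected, though a change within the scatter would be no surprise. The estimated step is a 1.5-fold higher number from compound 2 to compound 3 (0.17 log units; within the scatter). For compound 3 the expected value is 8000 nM, with an estimated range from 2500 nM to 25000 nM.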

Compound 3, half-maximal inhibitory concentration: 11000 nM
The estimate for compound 3 lay 1.4-fold (0.14 log units) below the measured number; the measured number falls inside the stated range.
By their numbers in this assay, from the lowest: compound 2; then compound 3; then compound 1.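

In this assay, replacing 1H-imidazol-1-yl with pyrazin-2-yl on the aromatic carbon next to the ring nitrogen gives a 2.0-fold higher number from compound 2 to compound 3 (0.31 log units; beyond the scatter) while the shared core and the ethyl group stay the same. Going by these compounds alone, this is the first direct reading of this position, and it shows that the number here responds to the choice of ring, with the five-membered ring giving the stronger inhibition of this pair. The change is modest even though the six-membered ring adds one heavy atom, and both groups are uncharged aromatic rings with two hetero atoms and the same counts of hydrogen-bond donors and acceptors; nothing available bears on what lies behind the shift.

A single pair of rings leaves open how far this trend extends, for instance whether a plain phenyl ring with no ring nitrogen, or a non-aromatic amine such as morpholine, would give a lower or a higher number at this carbon. On these data alone, it also remains open whether a longer chain in place of the ethyl group would change the number when the ring at this position stays the same.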